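A few compounds are considered here, and "the series" means these few. Any claim that something is new, unique, unknown or untested is made for them only; others in the source may bear on it.

Working notes on the series. Three measured compounds share one core and differ only in the substituent on the benzamide ring: compound 1 `COc1cc2oc(-c3cccc(NC(=O)c4ccc(Cl)cc4)c3)cc(=O)c2c(OC)c1OC`, compound 2 `COc1cc2oc(-c3cccc(NC(=O)c4cccc(Br)c4)c3)cc(=O)c2c(OC)c1OC` and compound 3 `COc1cc2oc(-c3cccc(NC(=O)c4ccc(Br)cc4)c3)cc(=O)c2c(OC)c1OC`. In a functional assay on UO-31 cells (Homo sapiens) for inhibition, read by sulforhodamine B assay, tested at 10 uM (on this read-out lower numbers stand for less inhibition and higher numbers for more inhibition at the one concentration tested (going by the name of the read-out)), compound 1 gives 51.1%. Compound 2 is recorded in this assay only as "active" (no number reported), with no number behind it. For the measured compounds named here, compound 3 gives 63.6% in this assay, the higher of the two numbers available; the single-point change a number 12.5 percentage points higher from compound 1 to compound 3 (beyond the scatter) is the only measured step in the set, modest in size but beyond the scatter.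

The next compound, compound 4 `COc1cc2oc(-c3cccc(NC(=O)c4ccc([N+](=O)[O-])cc4)c3)cc(=O)c2c(OC)c1OC`, has not yet been measured. It differs from compound 3 by nitro in place of bromo on an aromatic carbon. Going by the values given here, no measured step bears directly on this change: the step of a number 12.5 percentage points higher from compound 1 to compound 3 (beyond the scatter) exchanges one halogen for another and says nothing about a nitro group in that position, and compound 2 contributes no number at all. The expectation is therefore anchored on compound 3 alone, with a step of a number 6.6 percentage points lower from compound 3 to compound 4 (within the scatter) that is expected to stay within the usual scatter, direction undetermined. For compound 4 the estimated value in this assay is 57%, within a range from 35% to 78%, pending measurement.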

Compound 4, a percentage reported as inhibition, at one concentration (the size of the read-out at that concentration, not a potency): "active" (no number reported)
For compound 4 the study gives words and no number; no gap can be computed for the estimate.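

In this assay, for the compounds shown here, compound 4 is recorded only as "active", like compound 2, so no step from compound 3 to compound 4 can be read. Nothing available bears on this result. The compounds shown leave open whether 4-nitrophenyl gives more, less or similar inhibition than 4-bromophenyl on the shared core.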